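This account rests on a few compounds, and the source may have more. Where it says the series, first, only, none or still open, it means among the compounds named here.

Of the compounds shown here, two have been measured in a functional assay on MGC-803 cells (Homo sapiens) for cytotoxicity, read by MTT assay, with a stated time of 48 h; on this read-out higher numbers stand for weaker inhibition and lower numbers for stronger inhibition. Compound 1 `CC(=O)Oc1ccccc1C1CC(C)=NN1C(=O)CN1CCC(C(C)=O)CC1` gives 4120 nM in this assay. Compound 2 `Cc1ccc(C(=O)N2N=C(c3cc4ccccc4oc3=O)CC2c2ccccc2)cc1` gives 31300 nM in this assay, which is the higher of the two numbers, so compound 2 is the weaker inhibitor of the pair, and its distance from compound 1 lies beyond the usual scatter of repeated measurements.

Compound 3 `CC1CC(C)CN(CC(=O)N2N=C(c3cc4ccccc4oc3=O)CC2c2ccccc2)C1` has not yet been measured. It differs from compound 2 in a single place: (3,5-dimethylpiperidin-1-yl)methyl in place of 4-methylphenyl on a carbonyl carbon. Among the compounds with values here, no pair of measured compounds differing in just one place is available, so the size of this step cannot be read directly from a measured example and has to be judged from what the two measured compounds show.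

The step from compound 2 to compound 3 is expected to run downward, toward stronger inhibition, by about a 3.5-fold lower number from compound 2 to compound 3 (0.54 log units; beyond the scatter), because compound 1 also bears a piperidine-type ring and gives 4120 nM. Compound 3 is therefore estimated at 9000 nM in this assay, with a plausible range from 2500 nM to 30000 nM.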

Compound 3, half-maximal inhibitory concentration: "not active" (no number reported)
No number was reported for compound 3; no gap can be computed for the estimate.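

Compound 3 is reported only as "not active", with no number, so the step from compound 2 to compound 3 cannot be read. No further data bear on this result. As far as these compounds go, what stays open is how large an effect, in numbers, replacing 4-methylphenyl with (3,5-dimethylpiperidin-1-yl)methyl has on inhibition.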